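The source may report more compounds than this note shows. Statements on the series, on what has been measured and on what is new or still open speak of the compounds shown alone.

Compound 1, `O=C(Nc1cccc(-c2nc(-c3ccc(NC(=O)c4cccnc4)cc3Cl)no2)c1)Nc1cccc(C(F)(F)F)c1`, in a functional assay on MDA-MB-231 cells (Homo sapiens) for antiproliferative activity, read by MTT assay, with a stated time of 72 h; on this read-out lower numbers stand for stronger inhibition and higher numbers for weaker inhibition: 1900 nM
Compound 2, `C#Cc1cccc(NC(=O)Nc2cccc(-c3nc(-c4ccc(NC(=O)c5cccnc5)cc4Cl)no3)c2)c1`, in this assay: > 10000 nM
Compound 3, `NS(=O)(=O)Nc1ccc(NC(=O)Nc2cccc(-c3nc(-c4ccc(NC(=O)c5cccnc5)cc4Cl)no3)c2)cc1`, in this assay: 8900 nM

Three compounds share one core and differ only in the aryl group on the urea nitrogen. Compound 1 gives the lower of the two numbers. Compound 2 reaches only a limit of this assay, not a number (the limit of > 10000 nM in this assay, at which 1 of the 3 values shown sits). Compound 3 stands at the highest of the two numbers, with compound 1 as its nearest neighbour: the step of a 4.7-fold higher number from compound 1 to compound 3 (0.67 log units; beyond the scatter) lies beyond the scatter, while the step of an at least 1.1-fold lower number from compound 2 to compound 3 (0.05 log units; that floor lies within the scatter) does not.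

Compound 4, `CS(=O)(=O)Nc1ccc(NC(=O)Nc2cccc(-c3nc(-c4ccc(NC(=O)c5cccnc5)cc4Cl)no3)c2)cc1Cl`, has not yet been measured. It differs from compound 3 by 3-chloro-4-(methanesulfonamido)phenyl in place of 4-(sulfamoylamino)phenyl on an amide-type nitrogen. Within the data shown here, the steps that bear on it are those at the same nitrogen, a 4.7-fold higher number from compound 1 to compound 3 (0.67 log units; beyond the scatter) and an at least 5.2-fold higher number from compound 1 to compound 2 (0.72 log units; beyond the scatter), both modest and both away from compound 1. Among the measured compounds shown here, no measured pair isolates either the chlorine or the methanesulfonamido group, so the direction is open. Compound 4 is expected to give about 6500 nM, within 2200 nM to 16000 nM, a step of a 1.4-fold lower number from compound 3 to compound 4 (0.14 log units; within the scatter) that is estimated to stay within the scatter.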

Compound 4, half-maximal inhibitory concentration: 600 nM
The estimate for compound 4 lay 11-fold (1.03 log units) above the measured number, outside the stated range (below it).
By their numbers in this assay, from the lowest: compound 4; then compound 1; then compound 3. At a limit, above all of these: compound 2.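

At this amide-type nitrogen, the aryl group can lower the number as well as raise it: both earlier steps away from compound 1 went upward, whereas a 3.2-fold lower number from compound 1 to compound 4 (0.50 log units; beyond the scatter) runs the other way. In this assay, a sulfonyl-bearing aryl group is thus not tied to weak inhibition, as a 15-fold lower number from compound 3 to compound 4 (1.17 log units; beyond the scatter) separates two such groups, and an at least 16-fold lower number from compound 2 to compound 4 (1.22 log units; beyond the scatter) is large as well. That last step has only a floor, as compound 2 stands at a limit and not at a number: the limit of > 10000 nM in this assay, at which 1 of the 4 values shown sits.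

The step to compound 4 changes the chlorine and the methanesulfonamido group together, so the share of each cannot be separated. The compounds shown also leave open how a 4-(methanesulfonamido)phenyl group without the chlorine, or an aryl group carrying an amine or a carboxylic acid, would read at this nitrogen.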